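This account rests on a few compounds, and the source may have more. Where it says the series, first, only, none or still open, it means among the compounds named here.

Measured in a functional assay on CCRF-CEM cells (Homo sapiens) for inhibition; on this read-out higher numbers stand for weaker inhibition and lower numbers for stronger inhibition:
- Compound 1 `COc1cc2nc(-c3cccc(N4CCN(C)CC4)c3)cc(O)c2cc1-c1cnco1`: 1700 nM
- Compound 2 `COc1cc2nc(-c3ccc(N4CCN(C)CC4)cc3)cc(O)c2cc1-c1cnco1`: 2200 nM

Only these two numbers are available so far. For the measured compounds named here, compound 1 at 1700 nM and compound 2 at 2200 nM lie within the usual scatter of each other, so compound 1 stands level with the only other measured compound.

Compound 3 `COc1cc2nc(-c3cccc(N4CCCC4)c3)cc(O)c2cc1-c1cnco1` keeps the core of compound 1 but carries pyrrolidin-1-yl in place of 4-methylpiperazin-1-yl on an aromatic carbon. Going by the values given here, no measured pair of compounds shows what this exchange does, so any forecast remains uncertain. With nothing to point either way, no step beyond the scatter is expected in this assay. The estimated step is a 1.5-fold higher number from compound 1 to compound 3 (0.17 log units; within the scatter). For compound 3 the expected value is 2500 nM, with an estimated range of 800 nM to 8000 nM.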

Compound 3, half-maximal inhibitory concentration: 2700 nM
Compound 3: the middle estimate sits 1.1-fold (0.03 log units) below what was measured; the range from low to high includes it.
By their numbers in this assay, from the lowest: compounds 1, 2 and 3 (each within the scatter of the next).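

In this assay, putting pyrrolidin-1-yl in place of 4-methylpiperazin-1-yl on this aromatic carbon gives a 1.6-fold higher number from compound 1 to compound 3 (0.20 log units; within the scatter) and so leaves the two compounds level. For the compounds shown here, this is the first exchange of the group itself at this place, and it shows that the second ring nitrogen and the methyl group of compound 1 are not needed to keep the number at this level, at least in this single comparison. No measurement at hand explains this result.

Going by these compounds, it remains open whether an open-chain amine such as dimethylamino, or a carboxylic acid, on this carbon would move the number beyond the scatter. On these data alone, it also remains open whether pyrrolidin-1-yl would behave the same way if it replaced the 4-methylpiperazin-1-yl of compound 2.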